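From Methyl to Benzyl: Expectation for Compound 3

The source may report more compounds than this note shows. Statements on the series, on what has been measured and on what is new or still open speak of the compounds shown alone.

compound 1, `O=C(NC1CCCCC1)Oc1cccc(C2=NCCO2)c1`: 22%
compound 2, `C[C@H]1COC(c2cccc(OC(=O)NC3CCCCC3)c2)=N1`: 28%

In an assay on membranes from cerebellum (strain Wistar) for inhibition of Monoglyceride lipase (Rattus norvegicus), read by HPLC, tested at 100 uM (on this read-out lower numbers stand for less inhibition and higher numbers for more inhibition at the one concentration tested (going by the name of the read-out)), compound 1 gives 22%, and compound 2 gives 28%. Going by the values given here, the only step measured so far, a number 6 percentage points higher from compound 1 to compound 2 (within the scatter), lies within the scatter, so compound 2 and compound 1 cannot be told apart on these numbers; compound 2 simply stands as one of two values that agree with each other.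

Compound 3, `O=C(NC1CCCCC1)Oc1cccc(C2=N[C@@H](Cc3ccccc3)CO2)c1`, differs from compound 2 by phenyl in place of hydrogen on a saturated chain carbon bound to a saturated ring carbon. Among the compounds with values here, the one measured step bears on this change only loosely, since it added a methyl where compound 3 adds a benzyl, and that step was within the scatter. Within the data shown here, no measured step shows what a phenyl at this place does. Compound 3 is therefore expected to give 30% (range 10% to 55%), a step of a number 2 percentage points higher from compound 2 to compound 3 (within the scatter), with no change beyond the scatter expected.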

Compound 3, a percentage reported as inhibition, at one concentration (the size of the read-out at that concentration, not a potency): 17%
Estimate against measurement, compound 3: 13 percentage points above, within the range that was stated.
By their numbers in this assay, from the lowest: compounds 3, 1 and 2 (each within the scatter of the next, the first and the last beyond it).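

In this assay, going by these compounds alone, the phenyl on a saturated chain carbon bound to a saturated ring carbon gives the first step at this position that lies beyond the scatter, a number 11 percentage points lower from compound 2 to compound 3 (beyond the scatter). The unsubstituted ring carbon and the benzyl cannot be told apart, however, with a number 5 percentage points lower from compound 1 to compound 3 (within the scatter), so the change counts only against the methyl of compound 2, and only modestly. Nothing available explains this difference.

The compounds shown leave open whether another group on the saturated ring carbon, such as an amine, a carboxylic acid or a longer chain, would move the number beyond the scatter relative to compound 1. Since every reading comes from a single concentration, they also leave open whether the step between the methyl and the benzyl would hold at other concentrations.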